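The compounds below may be only part of what the source reports. "The series", "measured", "known", "first", "only" and "open" are said of these compounds alone.

Series values so far, with a functional assay on HepG2 cells (Homo sapiens) for inhibition, read by MTT assay, with a stated time of 72 h, tested at 30 uM (on this read-out lower numbers stand for less inhibition of growth and higher numbers for more inhibition of growth at the one concentration tested), as the read-out:
- compound 1 `C=CCc1ccc(OCc2cn(-c3ccc(C#N)cc3)nn2)c(O)c1` gives 1.5%
- compound 2 `C=CCc1ccc(OCc2cn(-c3ccccc3CO)nn2)c(O)c1` gives 4.2%

Compound 2 does not stand apart from compound 1 on these numbers. For the measured compounds named here, the only measured step is a number 2.7 percentage points higher from compound 1 to compound 2 (within the scatter) for 2-(hydroxymethyl)phenyl in place of 4-cyanophenyl on an aromatic nitrogen.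

Next comes compound 3 `C=CCc1ccc(OCc2cn(-c3cccc(C#N)c3)nn2)c(O)c1` with 3-cyanophenyl in place of 2-(hydroxymethyl)phenyl on an aromatic nitrogen, counted as 3-cyanophenyl in place of 2-(hydroxymethyl)phenyl on an aromatic nitrogen for this change. Going by the values given here, no measured compound carries 3-cyanophenyl, so the single step between a cyanophenyl and 2-(hydroxymethyl)phenyl is the only guide. With that step at a number 2.7 percentage points higher from compound 1 to compound 2 (within the scatter) as the basis, no shift beyond the scatter is expected in this assay for this change. The expected change is a number 0.2 percentage points lower from compound 2 to compound 3 (within the scatter) and nothing larger. For compound 3 the estimated value is 4% with -3% to 15% as the expected range.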

Compound 3, percent growth inhibition at one concentration: 2.3%
For compound 3 the middle estimate is 1.7 percentage points above the measured one; low and high end bracket the measured number.
By their numbers in this assay, from the lowest: compounds 1, 3 and 2 (each within the scatter of the next).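

In this assay, 3-cyanophenyl in place of 4-cyanophenyl on an aromatic nitrogen gives a number 0.8 percentage points higher from compound 1 to compound 3 (within the scatter), so these two placings of the nitrile are not told apart at this position. 3-cyanophenyl in place of 2-(hydroxymethyl)phenyl gives a number 1.9 percentage points lower from compound 2 to compound 3 (within the scatter), so exchanging the group with a hydrogen-bond donor for one with none also produces no shift beyond the scatter. No measurement is available that explains these results.

Going by these compounds, whether an amine, a carboxylic acid or a longer chain on this aromatic ring would give a number beyond the scatter remains open. The shared core is the same in all three compounds, so what it contributes to these numbers cannot be judged from them.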